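Chloro to Trifluoromethyl on the Aniline of Compound 3

The source may hold more compounds than are shown below. What is called first, only, known or untested is meant among the compounds shown, and "the series" means these compounds.

Measured so far:
compound 1, `O=C(/C=C\Nc1ccc(C(F)(F)F)cc1)c1cn(-c2ccccc2)nc1-c1ccccc1`: > 50000 nM
compound 2, `O=C(/C=C\Nc1ccc(C(F)(F)F)cc1)c1cn(-c2ccccc2)nc1-c1ccc(F)cc1`: > 50000 nM
compound 3, `COc1cc(-c2nn(-c3ccccc3)cc2C(=O)/C=C\Nc2ccc(Cl)cc2)cc(OC)c1OC`: 30200 nM

Of the compounds shown here, three have been tested in an ADME assay on HaCaT cells (Homo sapiens) for antiproliferative activity, read by MTT assay, with a stated time of 48 h; on this read-out lower numbers stand for stronger inhibition and higher numbers for weaker inhibition. Compound 1 returns only a limit of the assay, > 50000 nM. Compound 2 likewise returns only a limit, > 50000 nM. Among the compounds with values here, compound 3 is the single compound with an actual number, 30200 nM, and it alone offers a fixed point to reason from. Within the data shown here, the one step between measured compounds, a step that the two limits leave unreadable from compound 1 to compound 2, cannot be sized, since both ends are limits.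

Compound 4, `COc1cc(-c2nn(-c3ccccc3)cc2C(=O)/C=C\Nc2ccc(C(F)(F)F)cc2)cc(OC)c1OC`, differs from compound 3 in one place: trifluoromethyl in place of chloro on an aromatic carbon. Among the measured compounds shown here, no measured pair shows this exact change. The nearest evidence is the limit of > 50000 nM in this assay, at which 2 of the 3 values shown sit, where both compounds that already carry a trifluoromethyl on the aniline ring, compound 1 and compound 2, sit, while compound 3 with its chloro yields a number. This hints at weaker inhibition for compound 4, though the limits leave the amount open. The step from compound 3 to compound 4 in this assay is expected to be a 1.4-fold higher number from compound 3 to compound 4 (0.14 log units; within the scatter), toward weaker inhibition. Compound 4 is therefore expected to give about 42000 nM, within 15000 nM to 110000 nM, with a real chance that only a limit is reported.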

Compound 4, half-maximal inhibitory concentration: > 50000 nM
Compound 4: no number, only a limit (the forecaster's own chance of this, stated with the estimate: 50%); at least 1.1-fold (0.07 log units) between middle value and limit.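

In this assay, within the data shown here, trifluoromethyl in place of chloro on the aniline ring, para to a large group, gives an at least 1.6-fold higher number from compound 3 to compound 4 (0.21 log units; that floor lies within the scatter), the first step at this position that can be read at all, and it can be read only as a floor. Compound 4 gives > 50000 nM, which is a limit, even though it carries the same 3,4,5-trimethoxyphenyl group as compound 3. The steps from compound 1 and from compound 2 to compound 4 cannot be read, as both ends of each are limits, yet all three compounds with trifluoromethyl on the aniline ring now sit together, and the only number shown belongs to compound 3 with its chloro: the limit of > 50000 nM in this assay, at which 3 of the 4 values shown sit.

From the compounds shown here alone, how far past the limit compound 4 really lies remains unknown, so the true size of this step could be small or large. Going by these compounds, it is also open whether chloro itself matters at this position or whether another group there, such as a nitrile, an amine or a bromine atom, would also give a readable number on this core.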